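The source may report more compounds than this note shows. Statements on the series, on what has been measured and on what is new or still open speak of the compounds shown alone.

Compound 1 `O=C(O)c1ccc(C(=O)/C(=C\c2ccc(F)c([N+](=O)[O-])c2)SCc2ccc(F)cc2)cc1`, compound 2 `O=C(O)c1ccc(C(=O)/C(=C\c2ccc(Cl)c([N+](=O)[O-])c2)SCc2ccccc2F)cc1` and compound 3 `O=C(O)c1ccc(C(=O)/C(=C\c2ccc(Br)c([N+](=O)[O-])c2)SCc2ccc(Br)cc2)cc1` share one core and were each examined in a physicochemical assay for solubility; on this read-out lower numbers stand for lower solubility and higher numbers for higher solubility. In this assay compound 1 gives only a limit of the assay, < 1000 ug/mL. Compound 2 likewise gives a limit, < 1000 ug/mL. Compound 3 also gives a limit, < 1000 ug/mL, so its solubility is known only as sitting at that limit. No number places compound 3 against its two companions, because of the limit of < 1000 ug/mL in this assay, at which 3 of the 3 values shown sit. Among the measured compounds shown here, no step between measured compounds can therefore be drawn.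

Compound 4 `O=C(O)c1ccc(C(=O)/C(=C\c2ccc(O)c(Br)c2)SCc2ccc(Br)cc2)cc1` differs from compound 3 in one place: 3-bromo-4-hydroxyphenyl in place of 4-bromo-3-nitrophenyl on a double-bonded chain carbon bound to a double-bonded chain carbon. For the measured compounds named here, with every value so far resting at the limit of the assay, no measured step shows what such a change does to solubility, and the expectation for compound 4 can only be a reading that again falls at or inside the same limit. The step from compound 3 is estimated as a step that the limit leaves unreadable from compound 3 to compound 4, an expected placement and not a measured one. Compound 4 is thus expected at 300 ug/mL, with a range from 30 ug/mL to 1000 ug/mL.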

Compound 4, solubility: < 1000 ug/mL
Compound 4 gave a limit, no number (the forecaster's own chance of this, stated with the estimate: 75%); the middle value does not contradict the limit.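

No step can be read from compound 3 to compound 4, because both values are limits and not numbers: the limit of < 1000 ug/mL in this assay, at which 4 of the 4 values shown sit.

The compounds shown leave open what 3-bromo-4-hydroxyphenyl in place of 4-bromo-3-nitrophenyl does in this assay, and where the solubility of each compound actually lies.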